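Changing the Group on the Ring Nitrogen of Compound 1

The source may report more compounds than this note shows. Statements on the series, on what has been measured and on what is new or still open speak of the compounds shown alone.

Three compounds have been measured in a functional assay on PC-3 cells (Homo sapiens) for inhibition, read by sulforhodamine B assay, with a stated time of 48 h, tested at 50 uM; a higher number here means more inhibition of growth at the concentration tested, a lower number less inhibition of growth:
compound 1 `COc1ccc([C@@H]2C/C(=N/OCc3cn(-c4ccc(Cl)cc4C)nn3)c3cc(CC=C(C)C)c(OC)cc3O2)cc1` gives 49%
compound 2 `COc1cc2c(cc1CC=C(C)C)C(=O)C[C@@H](c1ccc(Oc3ccccc3)cc1)O2` gives 53%
compound 3 `C#CCOc1ccc([C@@H]2CC(=O)c3cc(CC=C(C)C)c(OC)cc3O2)cc1` gives 52%

Compound 1 sits within the scatter of both compound 3, the nearest of the three, and compound 2, the furthest; none of the three can be set apart from the others on these numbers. Among the compounds with values here, the one measured step, a number 1 percentage points lower from compound 2 to compound 3 (within the scatter), concerns a group on an oxygen on an aromatic ring and has no bearing on the ring nitrogen.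

Compound 4 `COc1ccc([C@@H]2C/C(=N/OCc3cn(-c4cc(OC)c(OC)c(OC)c4)nn3)c3cc(CC=C(C)C)c(OC)cc3O2)cc1` differs from compound 1 in one place: 3,4,5-trimethoxyphenyl in place of 4-chloro-2-methylphenyl on an aromatic nitrogen. Within the data shown here, no measured step touches this position, so the record gives no direction for it. Among the measured compounds shown here, the only step seen in this assay lay within the scatter, and a change at an untested position offers no reason to expect more. Compound 4 is therefore expected to give about 50% in this assay, in a range from 35% to 65%. This estimate means a number 1 percentage points higher from compound 1 to compound 4 (within the scatter), a step expected to stay within the scatter.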

Compound 4, percent growth inhibition at one concentration: 36%
Estimate against measurement, compound 4: 14 percentage points above, and the stated range covers the measured number.
By their numbers in this assay, from the lowest: compound 4; then compounds 1, 3 and 2 (each within the scatter of the next).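

In this assay, within the data shown here, 3,4,5-trimethoxyphenyl in place of 4-chloro-2-methylphenyl on the aromatic nitrogen gave a number 13 percentage points lower from compound 1 to compound 4 (beyond the scatter), the first single change in this set to pass beyond the scatter. The group on this nitrogen therefore bears on the read-out, and here the larger group with its hydrogen-bond acceptors went with less inhibition of growth. Nothing available explains this drop or ties it to any property of the two groups.

On these data alone, this one pair swaps the chloro and methyl groups for three methoxy groups all at once, so it remains open which of these differences counts. Also open, as far as these compounds go, is how a plain phenyl or a benzyl on that nitrogen would compare, and whether any group there would raise the number above that of compound 1.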